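Dropping the Trifluoromethyl from a Weak Amide

This account rests on a few compounds, and the source may have more. Where it says the series, first, only, none or still open, it means among the compounds named here.

Compound 2 `COc1cc(-c2nn(-c3cccc(NC(=O)c4cccc(C(F)(F)F)c4)c3)cc2-c2ccncc2)ccc1Cl` is the starting point of this step. In a functional assay on SK-MEL-2 cells (Homo sapiens) for inhibition, read by sulforhodamine B assay, with a stated time of 48 h (on this read-out lower numbers stand for stronger inhibition of growth and higher numbers for weaker inhibition of growth), compound 2 gives > 50000 nM, which is a limit of the assay and not a measured number (the limit of > 50000 nM in this assay, at which 1 of the 2 values shown sits). Going by the values given here, compound 1 `O=C(Nc1cccc(-n2cc(-c3ccncc3)c(-c3ccc(Cl)c(O)c3)n2)c1)Nc1cccc(C(F)(F)F)c1` differs from compound 2 at more than one place, so no single step joins them; in this assay compound 1 gives 10800 nM. Compound 3 `COc1cc(-c2nn(-c3cccc(NC(=O)c4ccccc4)c3)cc2-c2ccncc2)ccc1Cl` arises from compound 2 by the change (hydrogen in place of trifluoromethyl on an aromatic carbon). Among the compounds with values here, no measured pair carrying this single change is available, so the size of the step rests on the limit alone. The step of a number no higher from compound 2 to compound 3 (the limit leaves the size open) is expected to stay within the scatter, with compound 3 remaining near or at the limit. Compound 3 is therefore estimated at 50000 nM, with a range from 20000 nM to 150000 nM, and it may well again return only a limit.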

Compound 3, concentration for total growth inhibition: 4970 nM
For compound 3 the middle estimate is 10-fold (1.00 log units) above the measured one, outside the stated range (below it).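

In this assay, hydrogen in place of trifluoromethyl on the aromatic carbon of the amide's phenyl ring gives an at least 10-fold lower number from compound 2 to compound 3 (1.00 log units; beyond the scatter). Going by these compounds alone, this is the first single change in the set, and it shows that this position bears on the read-out and that the plain benzoyl amide of compound 3 gives a measured value. Compound 2 gives a limit of the assay and not a number, so the step sets only a lower bound on the size of the change: the limit of > 50000 nM in this assay, at which 1 of the 3 values shown sits.

The compounds shown leave open whether a small group such as fluoro, an amine or a carboxylic acid at this position would read like hydrogen or like trifluoromethyl. They also leave open whether the same change would move the urea of compound 1 in the same direction.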